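Methoxy for Methyl on the Benzyl Arm

This account rests on a few compounds, and the source may have more. Where it says the series, first, only, none or still open, it means among the compounds named here.

The two measured compounds are read in a functional assay on MCF7 cells (Homo sapiens) for inhibition, read by MTT assay, with a stated time of 72 h; on this read-out lower numbers stand for stronger inhibition and higher numbers for weaker inhibition. Compound 1 `Cc1ccc(Cn2ccc(Nc3cc(C)nc4nc(SCc5ccc(Br)cc5)nn34)n2)cc1` gives 11300 nM, the higher of the two numbers; compound 2 `Cc1cc(Nc2cc(-c3ccccc3)[nH]n2)n2nc(SCc3ccc(Br)cc3)nc2n1` gives 2720 nM, a gap that lies beyond the usual scatter. Compound 3 `COc1ccc(Cn2ccc(Nc3cc(C)nc4nc(SCc5ccc(Br)cc5)nn34)n2)cc1` differs from compound 1 in one place: methoxy in place of methyl on an aromatic carbon. For the measured compounds named here, no measured pair shows this change, so the numbers give no step to lean on. In this assay the step of a 1.2-fold lower number from compound 1 to compound 3 (0.08 log units; within the scatter) is expected to stay within the scatter, in no fixed direction. Compound 3 is therefore estimated at 9500 nM, with a range from 3500 nM to 26000 nM.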

Compound 3, half-maximal inhibitory concentration: 14600 nM
Compound 3: middle estimate off by 1.5-fold (0.19 log units), on the low side; the measured number falls inside the stated range.
By their numbers in this assay, from the lowest: compound 2; then compounds 1 and 3 (each within the scatter of the next).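

In this assay, 4-methylbenzyl gives way to 4-methoxybenzyl with a 1.3-fold higher number from compound 1 to compound 3 (0.11 log units; within the scatter), the first step read at this position. The added oxygen on this aromatic carbon therefore leaves the number indistinguishable from that of the methyl compound, and the arm tolerates this exchange in this read-out. No measured evidence bears on this result. Still open, going by these compounds, is whether an amine, a carboxylic acid or a longer chain at the same carbon would shift the number beyond the scatter.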